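Para substituent swap on the aryl ring: nitro to ethoxycarbonyl

The source may report more compounds than this note shows. Statements on the series, on what has been measured and on what is new or still open speak of the compounds shown alone.

Compound 3 `Cc1cc(-c2nnc3n2CCCCC3)c(C)n1-c1ccc([N+](=O)[O-])cc1` gives 108 nM in an assay on isolated protein for inhibition of 15-hydroxyprostaglandin dehydrogenase [NAD(+)] (Homo sapiens), read by fluorescence, with a stated time of 15 min (on this read-out higher numbers stand for weaker inhibition and lower numbers for stronger inhibition), the highest number of the three measured. Compound 1 `Cc1cc(-c2nnc3n2CCCCC3)c(C)n1-c1ccc(Br)cc1` gives 48 nM and compound 2 `Cc1ccc(-n2c(C)cc(-c3nnc4n3CCCCC4)c2C)cc1` gives 34 nM; the steps of a 2.3-fold higher number from compound 1 to compound 3 (0.35 log units; beyond the scatter) and a 3.2-fold higher number from compound 2 to compound 3 (0.50 log units; beyond the scatter) both run toward weaker inhibition on introducing nitro, while a 1.4-fold lower number from compound 1 to compound 2 (0.15 log units; within the scatter) lies within the scatter. Compound 4 `CCOC(=O)c1ccc(-n2c(C)cc(-c3nnc4n3CCCCC4)c2C)cc1` differs from compound 3 by ethoxycarbonyl in place of nitro on an aromatic carbon. Going by the values given here, no measured step exchanges nitro for an ester, so the closest guide is the nitro penalty itself: removing nitro is expected to recover part of it, at most toward the numbers of compounds 1 and 2. Compound 4 is therefore expected near 70 nM, within 30 nM to 180 nM, a step of a 1.5-fold lower number from compound 3 to compound 4 (0.19 log units; within the scatter).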

Compound 4, half-maximal inhibitory concentration: 38 nM
For compound 4 the middle estimate is 1.8-fold (0.27 log units) above the measured one; the range from low to high includes it.
By their numbers in this assay, from the lowest: compounds 2, 4 and 1 (each within the scatter of the next); then compound 3.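

Ethoxycarbonyl in place of nitro, on an aromatic carbon para to a large group, gives a 2.8-fold lower number from compound 3 to compound 4 (0.45 log units; beyond the scatter), so the higher number of compound 3 does not extend to this larger group of 5 heavy atoms. Compound 4 stays level with the methyl and bromo compounds, with a 1.1-fold higher number from compound 2 to compound 4 (0.05 log units; within the scatter) and a 1.3-fold lower number from compound 1 to compound 4 (0.10 log units; within the scatter), leaving nitro alone apart among the four, although nitro and ethoxycarbonyl both count 2 hydrogen-bond acceptors. No measurement at hand explains the gap between nitro and ethoxycarbonyl.

Open, on these data alone, is whether a carboxylic acid, an amide or an amine at this position would stay level with compound 4. Also open, as far as these compounds go, is how a longer ester chain would read.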